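A few compounds are considered here, and "the series" means these few. Any claim that something is new, unique, unknown or untested is made for them only; others in the source may bear on it.

Of the compounds shown here, two have so far been measured in a physicochemical assay for acid dissociation. Compound 1 `Fc1ccccc1CN(Cc1nnn[nH]1)c1ccccc1` gives 4.22 in this assay. Compound 2 `COc1ccc(N(Cc2nnn[nH]2)Cc2ccc(Cl)cc2Cl)cc1` gives 4.29 in this assay. Compound 1 holds the lower of the two numbers, yet the two values lie within the scatter of each other, so no order between them can be claimed. Going by the values given here, no pair of measured compounds that differ in a single place is available, so no measured step can be drawn on.

Compound 3 `Fc1cccc(CN(Cc2nnn[nH]2)c2ccccc2)c1` has not yet been measured. It differs from compound 1 in one place: 3-fluorophenyl in place of 2-fluorophenyl on a saturated chain carbon bound to a nitrogen on an aromatic ring. The change moves a fluorine within a ring that sits on a saturated chain carbon bound to a nitrogen on an aromatic ring, far from the proton that the assay follows. With the two measured values lying within the scatter of each other, and the change leaving the same atoms joined differently, no step beyond the scatter is expected in either direction. Compound 3 is expected to give 4.25 in this assay, within the range 4 to 4.5. The step from compound 1 to compound 3 that this estimate implies, a number 0.03 log units higher from compound 1 to compound 3 (within the scatter), is expected to fall within the usual scatter.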

Compound 3, acid dissociation constant: 4.19
For compound 3 the middle estimate is 0.06 log units above the measured one; low and high end bracket the measured number.
By their numbers in this assay, from the lowest: compounds 3, 1 and 2 (each within the scatter of the next).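

In this assay, going by these compounds alone, 3-fluorophenyl in place of 2-fluorophenyl on a saturated chain carbon bound to a nitrogen on an aromatic ring gives a number 0.03 log units lower from compound 1 to compound 3 (within the scatter), the first step in this set that isolates a single place. The two measured compounds available earlier differed in more than one place, so they could not speak to this position, whereas this pair shows that, for this one change of the same atoms joined differently, the read-out does not separate the two fluorophenyl groups. Nothing at hand bears on the reason for this result.

Going by these compounds, this single step speaks only to a fluorine moved within one ring on the core of compound 1, so it remains open whether a different group at the same place, such as an amine, a carboxylic acid or a longer chain, would give a step beyond the scatter in this assay. The compounds shown also offer no single-place step anywhere else on the shared core, so how far this result holds beyond this position remains unknown.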